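The source may hold more compounds than are shown below. What is called first, only, known or untested is meant among the compounds shown, and "the series" means these compounds.

In a functional assay on A549 cells (Homo sapiens) for inhibition, read by MTT assay, with a stated time of 72 h, tested at 10 uM (a higher number here means more inhibition at the concentration tested (going by the name of the read-out), a lower number less inhibition), compound 3 `CCOC(=O)C1=C(Nc2ccc(C(F)(F)F)cc2)S/C(=C\c2ccc[nH]2)C1=O` gives 30.1%, the higher of the two numbers obtained, and its nearest neighbour compound 1 `CCOC(=O)C1=C(Nc2ccccc2)S/C(=C\c2ccc[nH]2)C1=O` gives 23.5%, the two lying within the scatter of each other a number 6.6 percentage points higher from compound 1 to compound 3 (within the scatter). Compound 2 `CCOC(=O)C1=C(Nc2ccc(Br)cc2)S/C(=C\c2ccc[nH]2)C1=O` shows only a limit of the assay, < 10% (the limit of < 10% in this assay, at which 1 of the 3 values shown sits). Compound 4 `CCOC(=O)C1=C(Nc2ccc(C)cc2)S/C(=C\c2ccc[nH]2)C1=O` differs from compound 3 by methyl in place of trifluoromethyl on an aromatic carbon. Among the compounds with values here, no measured step exchanges a methyl group; the steps on the aromatic carbon show a number at least 13.5 percentage points lower from compound 1 to compound 2 (beyond the scatter) and a number at least 20.1 percentage points higher from compound 2 to compound 3 (beyond the scatter), while a number 6.6 percentage points higher from compound 1 to compound 3 (within the scatter) stays within the scatter. Substituents there have thus ranged from no change to a loss, so a modest drop is expected for compound 4: a number 10.1 percentage points lower from compound 3 to compound 4 (beyond the scatter). Compound 4 is estimated at 20%, between 8% and 32%.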

Compound 4, a percentage reported as inhibition, at one concentration (the size of the read-out at that concentration, not a potency): 20.9%
Estimate against measurement, compound 4: 0.9 percentage points below; low and high end bracket the measured number.
By their numbers in this assay, from the lowest: compounds 4, 1 and 3 (each within the scatter of the next). At a limit, below all of these: compound 2.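

Methyl on this aromatic carbon, para to a large group, cannot be told apart from trifluoromethyl, a number 9.2 percentage points lower from compound 3 to compound 4 (within the scatter), or from hydrogen, a number 2.6 percentage points lower from compound 1 to compound 4 (within the scatter), in this assay. Bromo alone stands apart among the four substituents, with a number at least 10.9 percentage points higher from compound 2 to compound 4 (beyond the scatter), so the size of the group in the leaving or entering position does not by itself order these compounds. Compound 2 remains a limit of the assay and not a number: the limit of < 10% in this assay, at which 1 of the 4 values shown sits.

The compounds shown leave open whether the low reading is particular to bromo or would recur with chloro or iodo. They also leave open what an amine or a carboxylic acid on this carbon would give.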